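The source may report more compounds than this note shows. Statements on the series, on what has been measured and on what is new or still open speak of the compounds shown alone.

Working notes on the series, cinnamoyl-type chalcones on a shared aminothiazole core.

Compound 1 `COc1ccc(/C=C/C(=O)c2sc(Nc3ccc(Cl)c(Cl)c3)nc2C)cc1` sits at a limit: in a functional assay on Bel-7402 cells (Homo sapiens) for cytotoxicity, read by MTT assay (a lower number here means a stronger inhibitor, a higher number a weaker inhibitor), compound 1 gives > 25000 nM, which is a limit of the assay and not a number. Compound 2 `Cc1ccc(Nc2nc(C)c(C(=O)/C=C/c3ccccc3)s2)cc1` sits at a limit as well, giving > 25000 nM in this assay. Compound 3 `Cc1nc(Nc2ccc(Cl)c(Cl)c2)sc1C(=O)/C=C/c1ccc(Cl)cc1` likewise stands at a limit, with > 25000 nM in this assay. Among the measured compounds shown here, the single measured step, a step that the two limits leave unreadable from compound 1 to compound 3, has both ends at a limit and cannot be read; all three values shown sit at the limit of > 25000 nM in this assay, at which 3 of the 3 values shown sit. For the measured compounds named here, no measured step therefore bears on the next change in a readable way.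

Compound 4 `Cc1nc(Nc2ccc(Cl)cc2)sc1C(=O)/C=C/c1ccc(Cl)cc1` differs from compound 3 by hydrogen in place of chloro on an aromatic carbon. Going by the values given here, with every value in the set at the limit and the one step unreadable, there is no basis for expecting a readable gain; compound 4 is expected to give 30000 nM in this assay, within 8000 nM to 100000 nM. The expected step that the limit leaves unreadable from compound 3 to compound 4 is thus none beyond the scatter, and the assay will most likely again report only a limit.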

Compound 4, half-maximal inhibitory concentration: > 25000 nM
Compound 4 gave a limit, no number; the forecaster's own chance of this, stated with the estimate: 80%; the middle value is on the limit's open side.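

Compound 4 gives > 25000 nM in this assay, a limit and not a number, so the step from compound 3, 3,4-dichlorophenyl to 4-chlorophenyl, cannot be read: the limit of > 25000 nM in this assay, at which 4 of the 4 values shown sit. The compounds shown leave open which change on the shared core would give a number rather than a limit in this assay.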